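Compound 2 to compound 4: methyl on the aromatic oxygen

The source may report more compounds than this note shows. Statements on the series, on what has been measured and on what is new or still open speak of the compounds shown alone.

Going by the values given here, in a functional assay on U-251 cells (Homo sapiens) for cytotoxicity (on this read-out lower numbers stand for stronger inhibition of growth and higher numbers for weaker inhibition of growth), compound 2 `COc1ccc(C2=C(c3ccc(SC)cc3)CC3CCCN3C2=O)cc1OC(=O)CNC(=O)OC(C)(C)C` reads 6000 nM and is the higher of the two true numbers so far. Compound 3 `COc1ccc(C2=C(c3ccc(SC)cc3)CC3CCCN3C2=O)cc1OC(=O)C1CCCN1C(=O)OC(C)(C)C` reads 2000 nM and is its nearest neighbour. Compound 1 `COc1ccc(C2=C(c3cc(OC)c(OC)c(OC)c3)CC3CCCN3C2=O)cc1O` gives > 100000 nM as a limit of the assay and not a number.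

Compound 4 `COc1ccc(C2=C(c3ccc(SC)cc3)CC3CCCN3C2=O)cc1OC` is the next to be read. It departs from compound 2 by methyl in place of (((tert-butoxycarbonyl)amino)methyl)carbonyl on an oxygen on an aromatic ring and the change is methyl in place of (((tert-butoxycarbonyl)amino)methyl)carbonyl on an oxygen on an aromatic ring.

Among the compounds with values here, one measured step bears on this: a 3.0-fold lower number from compound 2 to compound 3 (0.48 log units; beyond the scatter) is modest and alters the group on the carbonyl carbon while the carbonyl stays. Loss of the whole chain has no measured precedent, and compound 1 differs from compound 4 in more than one place, so it offers no clean comparison.

Within the data shown here, with only that modest step as a guide, a large shift in this assay is not expected, and the direction is weakly held, leaning towards a slightly lower number. The expected change is a 1.5-fold lower number from compound 2 to compound 4 (0.18 log units; within the scatter) and it is not expected to exceed the scatter. For compound 4 the estimate is 4000 nM with an expected range from 700 nM to 25000 nM on this read-out.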

Compound 4, concentration for 50% growth inhibition: 300 nM
The estimate for compound 4 lay 13-fold (1.12 log units) above the measured number; the measured number lies below the stated range.
By their numbers in this assay, from the lowest: compound 4; then compound 3; then compound 2. At a limit, above all of these: compound 1.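

In this assay, the oxygen on the aromatic ring proves a far more responsive place than the earlier step indicated: a 20-fold lower number from compound 2 to compound 4 (1.30 log units; beyond the scatter), against a 3.0-fold lower number from compound 2 to compound 3 (0.48 log units; beyond the scatter) for a change confined to the group on the carbonyl carbon while the carbonyl stays. Compound 3 gives 2000 nM and compound 4 gives 300 nM, the lowest of the three numbers, so methyl in place of the whole acyl chain moves the read-out much further than the one variation of that chain shown so far. Nothing measured here accounts for the size of this step.

Open, from the compounds shown here alone, is whether the drop belongs to methyl itself or simply to the loss of the (((tert-butoxycarbonyl)amino)methyl)carbonyl chain: an ethyl ether, a longer alkyl ether or an ester carrying a free amine on the same oxygen would separate the two. Compound 1 differs from compound 4 in more than one place, so it does not settle what a free hydroxyl on this oxygen would give with the rest of compound 4 kept.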